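The compounds below may be only part of what the source reports. "The series", "measured", "known", "first", "only" and "open" are said of these compounds alone.

Measured so far in an assay on isolated protein for binding affinity to histamine H2 receptor (Homo sapiens); a higher number here means a weaker inhibitor, a lower number a stronger inhibitor:

Compound 1 `CCOC(=O)N1CCN(CCCOc2ccc(C(=O)c3ccc(F)cc3)cc2)CC1`, which gives 42700 nM.
Compound 2 `CCOC(=O)N1CCN(CCCOc2ccc(C(=O)c3cccc(F)c3F)cc2)CC1`, which gives 17400 nM.

Going by the values given here, compound 2 holds the lower of the two numbers; its only neighbour in this assay is compound 1, and the single measured step, a 2.5-fold lower number from compound 1 to compound 2 (0.39 log units; beyond the scatter), separates them, a change that swaps the fluorine pattern on the phenyl attached to the carbonyl carbon.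

Next in line is compound 3 `CCOC(=O)N1CCN(CCCOc2ccc(C(=O)c3ccc(C(C)(C)C)cc3)cc2)CC1`. Going from compound 2 to compound 3 the change is 4-(tert-butyl)phenyl in place of 2,3-difluorophenyl on a carbonyl carbon. Among the compounds with values here, this is a change of a different kind from the one measured step: that step exchanged one fluorinated phenyl for another, whereas here both fluorines leave and a tert-butyl group enters. The step from compound 1 to compound 2 is modest and bears only loosely on the present change, so no firm direction can be read from it. The expectation is therefore a step of about a 1.7-fold higher number from compound 2 to compound 3 (0.24 log units; within the scatter) in this assay, within or near the scatter, with wide uncertainty either way. On that basis compound 3 is estimated at 30000 nM in this assay, with a range from 8000 nM to 110000 nM.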

Compound 3, inhibition constant: 1550 nM
For compound 3 the middle estimate is 19-fold (1.29 log units) above the measured one; the whole stated range lies above it.
By their numbers in this assay, from the lowest: compound 3; then compound 2; then compound 1.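

In this assay, the phenyl on the carbonyl carbon proves able to carry a far larger step than the modest change among fluorine patterns, a 2.5-fold lower number from compound 1 to compound 2 (0.39 log units; beyond the scatter), had shown: an 11-fold lower number from compound 2 to compound 3 (1.05 log units; beyond the scatter). The cleanest reading comes from the exchange of a single group, tert-butyl in place of fluoro on an aromatic carbon, which gives a 28-fold lower number from compound 1 to compound 3 (1.44 log units; beyond the scatter); what that aromatic carbon carries therefore matters strongly in this small set, and the lowest number of the three belongs to the tert-butyl compound. No measured information is available to explain why the number falls this far.

From the compounds shown here alone, whether the large step is specific to tert-butyl remains open, since isopropyl, trifluoromethyl, methoxy or an unsubstituted phenyl could show if a smaller or differently built group at the same aromatic carbon retains it. Going by these compounds, it is also open whether the step carries over when the shared core changes elsewhere, for example with a longer chain in place of the propyl linker between the oxygen and the piperazine nitrogen.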